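The compounds below may be only part of what the source reports. "The series", "measured", "known", "first", "only" and "open" are said of these compounds alone.

Measured compounds:
compound 1 `COC(=O)[C@@]1(C)CCC=C2[C@@H]1CC[C@@H](C)[C@]2(C)Cc1c[nH]c2ccc(C)cc12`
compound 2 `COC(=O)[C@@]1(C)CCC=C2[C@@H]1CC[C@@H](C)[C@]2(C)Cc1c[nH]c2ccc(F)cc12`
compound 3 `COC(=O)[C@@]1(C)CCC=C2[C@@H]1CC[C@@H](C)[C@]2(C)Cc1c(C)[nH]c2ccc(C)cc12`

In a functional assay on A549 cells (Homo sapiens) for inhibition, read by sulforhodamine B assay, with a stated time of 48 h (on this read-out lower numbers stand for stronger inhibition of growth and higher numbers for weaker inhibition of growth), compound 1 gives 17000 nM. Compound 2 gives 6200 nM and compound 3 gives 26000 nM. Of the three numbers, compound 3 is separated beyond the scatter only from compound 2; compound 1 lies within the scatter of it. Compound 4 `COC(=O)[C@@]1(C)CCC=C2[C@@H]1CC[C@@H](C)[C@]2(C)Cc1c(C)[nH]c2ccc(OC)cc12` differs from compound 3 in one place: methoxy in place of methyl on an aromatic carbon. Within the data shown here, no measured step swaps methyl for methoxy. Among the measured compounds shown here, the only change at that aromatic carbon is a 2.7-fold lower number from compound 1 to compound 2 (0.44 log units; beyond the scatter), a modest shift; a 1.5-fold higher number from compound 1 to compound 3 (0.18 log units; within the scatter) sits elsewhere and stays within the scatter. A small step, likely within the scatter and if anything downward, is therefore expected in this assay, as a 1.6-fold lower number from compound 3 to compound 4 (0.21 log units; within the scatter). Compound 4 is estimated at 16000 nM, range 6000 nM to 40000 nM.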

Compound 4, concentration for 50% growth inhibition: 16000 nM
Beside the measured number, compound 4's estimate shows no gap at the digits printed; measured number inside the range.
By their numbers in this assay, from the lowest: compound 2; then compounds 4, 1 and 3 (each within the scatter of the next).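

In this assay, methoxy in place of methyl on this aromatic carbon, para to a fused ring, adds an oxygen and a hydrogen-bond acceptor, yet a 1.6-fold lower number from compound 3 to compound 4 (0.21 log units; within the scatter) stays unresolved from no change. Among these compounds, at this carbon, the only step beyond the scatter remains a 2.7-fold lower number from compound 1 to compound 2 (0.44 log units; beyond the scatter), which was read on a different background. Nothing available explains either result.

Still open, going by these compounds, is how an amine or a carboxylic acid at this carbon would read. It is also unknown whether fluoro in place of methyl gives a similar step on compound 3.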